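Notes on the step from compound 3 to compound 4

This account rests on a few compounds, and the source may have more. Where it says the series, first, only, none or still open, it means among the compounds named here.

compound 1 `COc1cccc(-n2nnc(-c3ccccc3NC(=O)c3ccc(NC(C)=O)cc3)n2)c1`: 725 nM
compound 2 `COc1cccc(-n2nnc(-c3ccccc3NC(=O)c3ccc(N=[N+]=[N-])cc3)n2)c1`: 558 nM
compound 3 `COc1cccc(-n2nnc(-c3ccccc3NC(=O)c3ccc(NC(=O)CBr)cc3)n2)c1`: 241 nM

In a functional assay on NCI-H460 cells (Homo sapiens) for positive allosteric modulation, read by MTT assay, with stated times of 2 h and 72 h, tested at 1 uM (on this read-out lower numbers stand for stronger inhibition and higher numbers for weaker inhibition), compound 3 has the lowest of the three numbers, at 241 nM. The next structure is compound 4 `COc1cccc(-n2nnc(-c3ccccc3NC(=O)Nc3ccc([N+](=O)[O-])cc3)n2)c1`, and the change is (4-nitrophenyl)amino in place of 4-(((bromomethyl)carbonyl)amino)phenyl on a carbonyl carbon. In words, (4-nitrophenyl)amino stands in place of 4-(((bromomethyl)carbonyl)amino)phenyl on a carbonyl carbon. For the measured compounds named here, no measured step covers this replacement, and no measured compound carries the (4-nitrophenyl)amino group.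

The nearest evidence is indirect. The measured steps are a 1.3-fold lower number from compound 1 to compound 2 (0.11 log units; within the scatter), a 3.0-fold lower number from compound 1 to compound 3 (0.48 log units; beyond the scatter) and a 2.3-fold lower number from compound 2 to compound 3 (0.36 log units; beyond the scatter). Only the two steps ending at compound 3 exceed the scatter, and both are modest. Compound 4 lacks the ((bromomethyl)carbonyl)amino group, so the gain seen in a 2.3-fold lower number from compound 2 to compound 3 (0.36 log units; beyond the scatter) is not expected to carry over. The expected change in this assay is therefore modest and towards a higher number, a 2.5-fold higher number from compound 3 to compound 4 (0.40 log units; beyond the scatter). For compound 4 the estimate is 600 nM, with an expected range of 200 nM to 1800 nM.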

Compound 4, half-maximal inhibitory concentration: 179 nM
Beside the measured number, compound 4's estimate is 3.4-fold (0.53 log units) above it; measured number outside the range, below it.
By their numbers in this assay, from the lowest: compounds 4 and 3 (each within the scatter of the next); then compounds 2 and 1 (each within the scatter of the next).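

In this assay, the substituent on this carbonyl carbon can change substantially without a readable shift, with a 1.3-fold lower number from compound 3 to compound 4 (0.13 log units; within the scatter), so the ((bromomethyl)carbonyl)amino group is not required for a number at the level of compound 3. For the compounds shown here, the (4-nitrophenyl)amino group also separates from the two weaker members, with modest steps in a 3.1-fold lower number from compound 2 to compound 4 (0.49 log units; beyond the scatter) and in a 4.1-fold lower number from compound 1 to compound 4 (0.61 log units; beyond the scatter), and it therefore matches the gain previously seen only with compound 3. No evidence on hand accounts for these results.

The (4-nitrophenyl)amino group enters as a single piece, so the compounds shown do not separate the contribution of its amino nitrogen from that of its nitro group. Also open, as far as these compounds go, is how this assay would read with an amine or a carboxylic acid in place of that nitro group.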